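The source may hold more compounds than are shown below. What is called first, only, known or untested is meant among the compounds shown, and "the series" means these compounds.

Measured compounds:
- Compound 1, `Oc1ccc(-c2cc(-c3ccccc3O)cc(-c3cccc(O)c3)n2)cc1`: 650 nM
- Compound 2, `Oc1cccc(-c2cc(-c3ccccc3O)nc(-c3ccccc3O)c2)c1`: 3420 nM
- Compound 3, `Oc1ccccc1-c1cc(-c2ccccc2O)nc(-c2ccccc2O)c1`: 2510 nM

In a functional assay on T47D cells (Homo sapiens) for cytotoxicity, read by CCK-8 assay, with a stated time of 4 days (on this read-out higher numbers stand for weaker inhibition and lower numbers for stronger inhibition), compound 3 gives the second highest of the three numbers. Its nearest neighbour is compound 2, and a 1.4-fold lower number from compound 2 to compound 3 (0.13 log units; within the scatter); the gap to compound 1 is larger and beyond the scatter, compound 1 showing the lowest number of the set.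

Compound 4, `Oc1ccc(-c2cc(-c3ccccc3O)cc(-c3ccccc3O)n2)cc1`, has not yet been measured. It differs from compound 3 by 4-hydroxyphenyl in place of 2-hydroxyphenyl on an aromatic carbon, the change sitting on an aromatic carbon of a six-membered aromatic ring with one nitrogen, next to the ring nitrogen and meta to two 2-hydroxyphenyl groups.

Among the compounds with values here, only one measured step touches the same position: a 1.4-fold lower number from compound 2 to compound 3 (0.13 log units; within the scatter), which exchanged one hydroxyphenyl isomer for another and stayed within the scatter. Within the data shown here, no measured pair exchanges 2-hydroxyphenyl for 4-hydroxyphenyl directly, but compound 1, the only compound carrying 4-hydroxyphenyl next to the ring nitrogen, shows the lowest number in this assay, while compound 2 and compound 3 carry other isomers there and show higher numbers.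

On that basis compound 4 is expected to give a modestly lower number than compound 3, a step of a 1.7-fold lower number from compound 3 to compound 4 (0.22 log units; within the scatter) that may still fall within the scatter. The estimate for compound 4 in this assay is 1500 nM, with a range from 600 nM to 4000 nM.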

Compound 4, half-maximal inhibitory concentration: 960 nM
For compound 4 the middle estimate is 1.6-fold (0.19 log units) above the measured one, and the stated range covers the measured number.
By their numbers in this assay, from the lowest: compounds 1 and 4 (each within the scatter of the next); then compounds 3 and 2 (each within the scatter of the next).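

In this assay, within the data shown here, a 2.6-fold lower number from compound 3 to compound 4 (0.42 log units; beyond the scatter) gives the first direct reading of 4-hydroxyphenyl in place of 2-hydroxyphenyl on this aromatic carbon, next to the ring nitrogen, and it lies beyond the scatter. The earlier compounds shown here only hinted at this, since compound 1 differs from compound 3 in more than one place; the new pair shows that moving the hydroxyl around this one phenyl ring, with the atom count unchanged, is enough to shift the number. The second step, a 1.5-fold higher number from compound 1 to compound 4 (0.17 log units; within the scatter), stays within the scatter, and compound 4 thus sits level with compound 1, so exchanging 3-hydroxyphenyl for 2-hydroxyphenyl leaves the number in place on both cores where it can be read: the same change on two cores in this assay, a 1.4-fold lower number (0.13 log units; within the scatter) from compound 2 to compound 3 and a 1.5-fold higher number (0.17 log units; within the scatter) from compound 1 to compound 4, 2.0-fold (0.30 log units) apart, within the scatter of two such steps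

As far as these compounds go, the gain from 4-hydroxyphenyl rests on this single pair, so whether it holds on any other core remains open. All the compounds shown carry only hydroxyphenyl groups, which leaves open whether the hydroxyl itself is needed, or whether an amine or a carboxylic acid in its place on the same ring would serve as well.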